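A Chloro Step Carried From One Core to Another

This account rests on a few compounds, and the source may have more. Where it says the series, first, only, none or still open, it means among the compounds named here.

Compound 1, `COc1ccc(-c2nc(SCC(=O)c3sc(-c4ccccc4)nc3C)nc(N)c2C#N)cc1`, gives 60.8% in a functional assay on U-87MG ATCC cells for antiproliferative activity against U-87 MG (Homo sapiens), read by MTT assay, with a stated time of 48 h, tested at 10 uM; a lower number here means a stronger effect, a higher number a weaker effect of the compound at the concentration tested.
Compound 2, `COc1ccc(-c2nc(SCC(=O)c3sc(-c4ccc(Cl)cc4)nc3C)nc(N)c2C#N)cc1`, gives 64.5% in this assay.
Compound 3, `COc1ccc(-c2nc(C)c(C(=O)CSc3nc(-c4ccccc4)c(C#N)c(=O)[nH]3)s2)cc1`, gives 90.9% in this assay.

The change chloro in place of hydrogen on an aromatic carbon gave a number 3.7 percentage points higher from compound 1 to compound 2 (within the scatter). Compound 3 differs from compound 1 in more than one place; the difference between the two cores is not broken down here. Compound 4, `COc1ccc(-c2nc(C)c(C(=O)CSc3nc(-c4cccc(Cl)c4)c(C#N)c(=O)[nH]3)s2)cc1`, comes from compound 3 by chloro in place of hydrogen on an aromatic carbon. It is the same kind of change as that from compound 1 to compound 2, but the chloro enters meta to a large group rather than para to a large group. Because the earlier step was a number 3.7 percentage points higher from compound 1 to compound 2 (within the scatter), a step of similar size is expected for compound 4 in this assay, namely a number 1.1 percentage points higher from compound 3 to compound 4 (within the scatter). Compound 4 is therefore estimated at 92%, between 82% and 100%.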

Compound 4, a percentage reported as activity, at one concentration (the size of the read-out at that concentration, not a potency): 90.6%
Beside the measured number, compound 4's estimate is 1.4 percentage points above it; the range from low to high includes it.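

On the core of compound 3, the change from phenyl to 3-chlorophenyl gave a number 0.3 percentage points lower from compound 3 to compound 4 (within the scatter) in this assay. The chloro step therefore carried from one core to the other without a measurable effect on either, and the two steps agree: the same change on two cores in this assay, a number 3.7 percentage points higher (within the scatter) from compound 1 to compound 2 and a number 0.3 percentage points lower (within the scatter) from compound 3 to compound 4, 4 percentage points apart, within the scatter of two such steps. Among these compounds, with only two such pairs, and the chloro in a different place in each, this does not show that chloro would leave the read-out unchanged elsewhere, and a read-out at one concentration is not a potency.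

The compounds shown leave open whether another group in that place, such as an amine or a carboxylic acid, would shift the number beyond the scatter. They also leave open which of the several differences between compound 1 and compound 3 accounts for the gap between those two cores.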